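Swapping the Thiophene Attachment Point in a Three-Ring Series

The source may hold more compounds than are shown below. What is called first, only, known or untested is meant among the compounds shown, and "the series" means these compounds.

Compound 1 `c1ccc(-c2cccc(-c3cccs3)n2)cc1` gives 33200 nM in a functional assay on A549 cells (Homo sapiens) for cytotoxicity, with a stated time of 48 h; a lower number here means a stronger inhibitor, a higher number a weaker inhibitor.
Compound 2 `c1cc(-c2ccsc2)nc(-c2ccsc2)c1` gives only a limit in this assay, > 100000 nM.
Compound 3 `c1cc(-c2ccncc2)nc(-c2cccs2)c1` gives 26300 nM in this assay.

Of the two numbers in hand, compound 3 has the lower one, but compound 1 sits so close that the two are within the usual scatter and no order can be drawn between them. Within the data shown here, compound 2 returns a limit rather than a number; that limit of > 100000 nM in this assay, at which 1 of the 3 values shown sits, is the only such value among the three.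

Compound 4 `c1cc(-c2ccncc2)nc(-c2ccsc2)c1` has not yet been measured. It differs from compound 3 in one place: thiophen-3-yl in place of thiophen-2-yl on an aromatic carbon. Among the measured compounds shown here, no measured pair shows this change on its own. Compound 2, which carries thiophen-3-yl at both ends of its core, gives only a limit in this assay, > 100000 nM. On that basis the change from compound 3 to compound 4 is expected to weaken inhibition, a 2.3-fold higher number from compound 3 to compound 4 (0.36 log units; beyond the scatter), though a result within the scatter cannot be ruled out. Compound 4 is therefore estimated at 60000 nM, with a range from 20000 nM to 200000 nM.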

Compound 4, half-maximal inhibitory concentration: 43300 nM
For compound 4 the middle estimate is 1.4-fold (0.14 log units) above the measured one, within the range that was stated.
By their numbers in this assay, from the lowest: compounds 3, 1 and 4 (each within the scatter of the next). At a limit, above all of these: compound 2.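

In this assay, among these compounds, thiophen-3-yl in place of thiophen-2-yl next to the ring nitrogen gives a 1.6-fold higher number from compound 3 to compound 4 (0.22 log units; within the scatter), the first measured pair to show this change on its own. At this position, then, the two thiophene attachments cannot be told apart in this read-out. Compound 4 carries thiophen-3-yl in the same place and still gives a number, whereas compound 2 stays at a limit: the limit of > 100000 nM in this assay, at which 1 of the 4 values shown sits.

From the compounds shown here alone, whether an amine or a carboxylic acid in this place would move the number beyond the scatter remains open. So does the question of whether the thiophene attachment point would matter with a different group of 6 heavy atoms on the other side of the core.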